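From trifluoromethyl to ethyl on a shared core

The compounds below may be only part of what the source reports. "The series", "measured", "known", "first", "only" and "open" are said of these compounds alone.

In a functional assay on KB-V1 cells (Homo sapiens) for cytotoxicity, read by MTT assay, with a stated time of 72 h (on this read-out higher numbers stand for weaker inhibition and lower numbers for stronger inhibition), compound 1 `O=C1Nc2ccccc2/C1=N/NC(=S)Nc1ccc(F)cc1` gives 1920 nM, and compound 2 `O=C1Nc2ccccc2/C1=N/NC(=S)Nc1ccc(C(F)(F)F)cc1` gives 2100 nM, so the two stand within the usual scatter of each other. Compound 3 `CCc1ccc(NC(=S)N/N=C2\C(=O)Nc3ccccc32)cc1` carries ethyl in place of trifluoromethyl on an aromatic carbon. Within the data shown here, only one measured step bears on this swap, a change of group at an aromatic carbon, and it is small: a 1.1-fold higher number from compound 1 to compound 2 (0.04 log units; within the scatter). No shift beyond the scatter is therefore expected in this assay. The estimated step is a 1.1-fold lower number from compound 2 to compound 3 (0.02 log units; within the scatter). For compound 3 the expected value is 2000 nM, with an estimated range of 900 nM to 4500 nM.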

Compound 3, half-maximal inhibitory concentration: 1340 nM
The estimate for compound 3 lay 1.5-fold (0.17 log units) above the measured number, within the range that was stated.
By their numbers in this assay, from the lowest: compounds 3, 1 and 2 (each within the scatter of the next).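

Until now, only groups bearing fluorine had been compared at this place on the shared core. In this assay ethyl, a group of carbon only, brings a 1.6-fold lower number from compound 2 to compound 3 (0.20 log units; within the scatter) and a 1.4-fold lower number from compound 1 to compound 3 (0.16 log units; within the scatter) so removing fluorine from this group altogether leaves all three compounds within the scatter. Nothing available explains why these three groups give such close numbers. On these data alone, whether an amine, a carboxylic acid or a longer chain at this place would stay as close remains open. So does whether this closeness would hold in other cells.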